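This account rests on a few compounds, and the source may have more. Where it says the series, first, only, none or still open, it means among the compounds named here.

In a functional assay on Caco-2 cells (Homo sapiens) for inhibition, read by MTT assay, with a stated time of 48 h, tested at 10 uM (on this read-out higher numbers stand for more inhibition of growth at the one concentration tested and lower numbers for less inhibition of growth), compound 1 `COc1ccc(COc2cc(O)c3c(=O)cc(C)oc3c2[C@H]2CCN(C)C[C@H]2O)cc1` gives 8% and compound 2 `Cc1cc(=O)c2c(O)cc(OCc3ccc([N+](=O)[O-])cc3)c([C@H]3CCN(C)C[C@H]3O)c2o1` gives 14% while compound 3 `Cc1cc(=O)c2c(O)cc(OC/C=C/c3ccccc3)c([C@H]3CCN(C)C[C@H]3O)c2o1` gives 9% so that compound 3 stands within the scatter of both others. Compound 4 `Cc1cc(=O)c2c(O)cc(OCc3ccco3)c([C@H]3CCN(C)C[C@H]3O)c2o1` has not yet been measured. It carries furan-2-yl in place of 2-phenylethenyl on a saturated chain carbon bound to an oxygen on an aromatic ring, a change counted as furan-2-yl in place of 2-phenylethenyl on a saturated chain carbon bound to an oxygen on an aromatic ring and so far untested. Two measured steps exchange the group at this place, a number 1 percentage points higher from compound 1 to compound 3 (within the scatter) and a number 5 percentage points lower from compound 2 to compound 3 (within the scatter) and neither leaves the scatter. The remaining step, a number 6 percentage points higher from compound 1 to compound 2 (within the scatter) on an aromatic carbon, also stays within it. Going by the values given here, no measured compound carries furan-2-yl, so these steps are only a weak guide, but none of them points to a shift, and no step beyond the scatter is expected in this assay for this change. The estimated step is a number 1 percentage points higher from compound 3 to compound 4 (within the scatter) and no clear direction is expected for it. Compound 4 is estimated at 10% with an expected range from 2% to 20% when it is measured.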

Compound 4, percent growth inhibition at one concentration: 17%
Compound 4: the middle estimate sits 7 percentage points below what was measured, within the range that was stated.
By their numbers in this assay, from the lowest: compounds 1, 3, 2 and 4 (each within the scatter of the next).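

In this assay, furan-2-yl on the saturated chain carbon bound to an oxygen on an aromatic ring gives a number 8 percentage points higher from compound 3 to compound 4 (within the scatter), a number 3 percentage points higher from compound 2 to compound 4 (within the scatter) and a number 9 percentage points higher from compound 1 to compound 4 (within the scatter). The earlier compounds shown here carried only six-membered aromatic rings of carbon only at this place, and the five-membered aromatic ring with 1 hetero atom now shows that this change of ring also produces no step beyond the scatter. No measurement at hand bears on the reason for these small differences.

Going by these compounds, it remains open whether a group of another kind at this place, such as a simple amine, a carboxylic acid or a longer saturated chain, would produce a step beyond the scatter. On these data alone, whether these four compounds would separate at any other concentration also stays open.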